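Allyl in Place of Phenyl on the Ring Nitrogen

The source may hold more compounds than are shown below. What is called first, only, known or untested is meant among the compounds shown, and "the series" means these compounds.

Measured compounds:
Compound 1, `Cn1c(-c2cc(-c3ccc(F)cc3F)ccc2O)n[nH]c1=S`, 56.9%.
Compound 2, `Oc1ccc(-c2ccc(F)cc2F)cc1-c1n[nH]c(=S)n1C1CCCCC1`, 64.4%.
Compound 3, `Oc1ccc(-c2ccc(F)cc2F)cc1-c1n[nH]c(=S)n1-c1ccccc1`, 36.3%.

All three were tested in a functional assay on the whole organism (strain BALB/c) for inhibition, with Mus musculus as the target, read by paw edema, with a stated time of 4 h, at a dose of 50 mg/kg by the oral route; on this read-out lower numbers stand for less inhibition and higher numbers for more inhibition at the one dose given (going by the name of the read-out). Compound 3 stands lowest of the three numbers: its nearest neighbour is compound 1, and the step of a number 20.6 percentage points lower from compound 1 to compound 3 (beyond the scatter) lies beyond the scatter, as does the step of a number 28.1 percentage points lower from compound 2 to compound 3 (beyond the scatter). The step of a number 7.5 percentage points higher from compound 1 to compound 2 (within the scatter), by contrast, lies within the scatter, so the methyl and cyclohexyl groups on the aromatic nitrogen cannot be told apart on these numbers.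

Compound 4, `C=CCn1c(-c2cc(-c3ccc(F)cc3F)ccc2O)n[nH]c1=S`, has not yet been measured. It differs from compound 3 as follows: allyl in place of phenyl on an aromatic nitrogen. Both steps that bear on this change point the same way: whenever phenyl sits on the aromatic nitrogen, the number in this assay is the lower one, whether the comparison is with methyl or with cyclohexyl. Allyl is a short open chain with no ring, closer in kind to methyl than to phenyl, so compound 4 is expected to recover a step of about a number 18.7 percentage points higher from compound 3 to compound 4 (beyond the scatter) upward, beyond the scatter. Compound 4 is therefore estimated at 55%, with a range from 40% to 70%.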

Compound 4, a percentage reported as inhibition, in the whole organism at one dose (the size of the read-out at that dose, not a potency): 73%
Beside the measured number, compound 4's estimate is 18 percentage points below it; the measured number lies above the stated range.
By their numbers in this assay, from the lowest: compound 3; then compounds 1, 2 and 4 (each within the scatter of the next, the first and the last beyond it).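

In this assay, allyl in place of phenyl on the aromatic nitrogen gives a large change (a number 36.7 percentage points higher from compound 3 to compound 4 (beyond the scatter)), so compound 3 now stands apart, beyond the scatter, from compounds carrying methyl, cyclohexyl or allyl at this position. The open chain of compound 4 and the cyclohexyl ring of compound 2 cannot be told apart here (a number 8.6 percentage points higher from compound 2 to compound 4 (within the scatter)), which shows that a ring on this nitrogen does not by itself go with the lower number, and that the low value belongs to phenyl among the groups shown. The comparison with methyl adds something new (a number 16.1 percentage points higher from compound 1 to compound 4 (beyond the scatter)): until now, no group on this nitrogen had stood above methyl beyond the scatter, as cyclohexyl had stayed within it.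

The compounds shown leave open whether the double bond of allyl matters, which a saturated propyl chain would test, and whether benzyl, with its ring set one carbon away from the nitrogen, would follow phenyl or the other groups. Nothing measured here explains any of these steps.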